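A few compounds are considered here, and "the series" means these few. Any claim that something is new, unique, unknown or untested is made for them only; others in the source may bear on it.

Of the compounds shown here, three that share one core have been measured in a functional assay on HEK293 cells for antagonist activity at Oxytocin receptor (Homo sapiens), read by calcium flux, with a stated time of 10 min, in the presence of a further agent that is not named here; on this read-out lower numbers stand for stronger inhibition and higher numbers for weaker inhibition. Compound 1 `COc1ccc(-n2c(COCCF)nnc2N2C[C@@H]3C[C@]3(c3ccc(F)cc3Cl)C2)cn1` gives 44 nM. Compound 2 `COc1ccc(-n2c(CO[C@H]3CCOC3)nnc2N2C[C@@H]3C[C@]3(c3ccc(F)cc3Cl)C2)cn1` gives 184 nM, and compound 3 `COc1ccc(-n2c(CO[C@@H]3CCOC3)nnc2N2C[C@@H]3C[C@]3(c3ccc(F)cc3Cl)C2)cn1` gives 223 nM. Compound 3 carries the highest number of the three, but a 1.2-fold higher number from compound 2 to compound 3 (0.08 log units; within the scatter) lies within the scatter, which fits (the fact that compounds 2 and 3 differ only in the configuration as drawn). The steps of a 4.2-fold higher number from compound 1 to compound 2 (0.62 log units; beyond the scatter) and a 5.1-fold higher number from compound 1 to compound 3 (0.70 log units; beyond the scatter) show the oxolanyl ether inhibiting more weakly than the fluoroethyl ether. Compound 4 `COc1ccc(-n2c(C(F)F)nnc2N2C[C@@H]3C[C@]3(c3ccc(F)cc3Cl)C2)cn1` takes the next step: difluoromethyl in place of ((oxolan-3-yl)oxy)methyl on an aromatic carbon. For the measured compounds named here, no measured step tests a difluoromethyl group directly; since the steps of a 4.2-fold higher number from compound 1 to compound 2 (0.62 log units; beyond the scatter) and a 5.1-fold higher number from compound 1 to compound 3 (0.70 log units; beyond the scatter) both run away from the oxolanyl ether, a move back toward lower numbers is expected for compound 4, a 3.7-fold lower number from compound 3 to compound 4 (0.57 log units; beyond the scatter). Compound 4 is therefore estimated at 60 nM, with a range from 15 nM to 250 nM.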

Compound 4, half-maximal inhibitory concentration: 52 nM
For compound 4 the middle estimate is 1.2-fold (0.06 log units) above the measured one, and the stated range covers the measured number.
By their numbers in this assay, from the lowest: compounds 1 and 4 (each within the scatter of the next); then compounds 2 and 3 (each within the scatter of the next).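

Difluoromethyl gives a 4.3-fold lower number from compound 3 to compound 4 (0.63 log units; beyond the scatter) and a 3.5-fold lower number from compound 2 to compound 4 (0.55 log units; beyond the scatter), so on this aromatic carbon neither the ring nor the ether oxygen of ((oxolan-3-yl)oxy)methyl is needed to reach the lower numbers. Set against (2-fluoroethoxy)methyl, the change gives a 1.2-fold higher number from compound 1 to compound 4 (0.07 log units; within the scatter), so the two groups cannot be told apart here. Nothing measured here bears on why this change acts as it does. From the compounds shown here alone, whether the fluorine atoms themselves count remains open. A plain methyl or a trifluoromethyl group on this carbon would test that.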